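Removing a methoxy from the amide-bearing pyridine ring

The compounds below may be only part of what the source reports. "The series", "measured", "known", "first", "only" and "open" are said of these compounds alone.

Compound 1 `COc1cc(F)c(NC(=O)c2ccncc2)cc1Nc1nccc(-c2cn(C)c3ccccc23)n1` and compound 2 `COc1cc(F)c(NC(=O)c2ccncc2OC)cc1Nc1nccc(-c2cn(C)c3ccccc23)n1` share one core; compound 3 `COc1ccc(C(=O)Nc2cc(Nc3nccc(-c4cn(C)c5ccccc45)n3)c(OC)cc2N(C)C)nc1` has a different core, and the difference between the two cores is not broken down here. In a functional assay on NCI-H1975 cells (Homo sapiens) for antiproliferative activity, read by MTT assay, with a stated time of 72 h (a lower number here means a stronger inhibitor, a higher number a weaker inhibitor), compound 1 gives 4370 nM and compound 2 gives 4120 nM. Compound 3 gives 2130 nM. Between compound 2 and compound 1 the change hydrogen in place of methoxy on an aromatic carbon made a 1.1-fold higher number from compound 2 to compound 1 (0.03 log units; within the scatter). Compound 4 `COc1cc(N(C)C)c(NC(=O)c2ccccn2)cc1Nc1nccc(-c2cn(C)c3ccccc23)n1` carries the same kind of change from compound 3, (hydrogen in place of methoxy on an aromatic carbon); the place differs, being para to a large group rather than ortho to a large group. Compound 4 is therefore expected near 2500 nM, a step of a 1.2-fold higher number from compound 3 to compound 4 (0.07 log units; within the scatter), because the earlier step gave a 1.1-fold higher number from compound 2 to compound 1 (0.03 log units; within the scatter). The estimate for compound 4 spans 1200 nM to 5500 nM.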

Compound 4, half-maximal inhibitory concentration: 10400 nM
Beside the measured number, compound 4's estimate is 4.2-fold (0.62 log units) below it, outside the stated range (above it).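

In this assay, replacing the methoxy with hydrogen on the 5-methoxypyridin-2-yl group gave a 4.9-fold higher number from compound 3 to compound 4 (0.69 log units; beyond the scatter). Going by these compounds alone, the size of this step therefore did not carry over from one core to the other: the same change on two cores in this assay, a 1.1-fold higher number (0.03 log units; within the scatter) from compound 2 to compound 1 and a 4.9-fold higher number (0.69 log units; beyond the scatter) from compound 3 to compound 4, 4.6-fold (0.66 log units) apart, beyond the scatter of two such steps This does not show whether the core or the place of the methoxy on the ring accounts for the gap, since the two pairs differ in both and each core offers only one pair.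

The compounds shown leave open how a different group at this place on the core of compound 3, such as an ethoxy or an amine, would compare with the methoxy. They also leave open whether a methoxy at the place it occupies in compound 2 would matter on that core.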